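A few compounds are considered here, and "the series" means these few. Any claim that something is new, unique, unknown or untested is made for them only; others in the source may bear on it.

Measured so far:
- compound 1 `O=C(/C=C/c1coc2cc(O)ccc2c1=O)NCc1ccccc1`: 63000 nM
- compound 2 `COc1ccc2c(=O)c(/C=C/C(=O)Nc3cc(C)ccc3C)coc2c1`: > 100000 nM

In a functional assay (QGY7701 cells, Homo sapiens) for inhibition, read by MTT assay, with a stated time of 48 h (on this read-out lower numbers stand for stronger inhibition and higher numbers for weaker inhibition), compound 1 gives a numerical value of 63000 nM. For compound 2 this assay records only a limit, > 100000 nM, so compound 2 stands at the limit of > 100000 nM in this assay, at which 1 of the 2 values shown sits, and no number is attached to it. Going by the values given here, no step between two measured compounds can be drawn here.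

Compound 3 `COc1ccc2c(=O)c(/C=C/C(=O)Nc3ccccc3OC)coc2c1` is the unmeasured member. It differs from compound 2 by 2-methoxyphenyl in place of 2,5-dimethylphenyl on an amide-type nitrogen. With compound 2 set at a limit, the change from compound 2 to compound 3 cannot be read against any measured step of the same kind, and compound 1 carries a different amide substituent, so it offers no direct guide either. The expectation is that compound 3 stays close to where compound 2 is, with the step from compound 2 to compound 3 estimated as an at least 1.1-fold lower number from compound 2 to compound 3 (0.04 log units; that floor lies within the scatter). Compound 3 is estimated at 90000 nM in this assay, expected to lie between 30000 nM and 250000 nM.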

Compound 3, half-maximal inhibitory concentration: 17600 nM
Compound 3: middle estimate off by 5.1-fold (0.71 log units), on the high side, and the stated range ends above it.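

In this assay, the group on the amide-type nitrogen is a place where a single change moves the read-out: 2-methoxyphenyl in place of 2,5-dimethylphenyl gives an at least 5.6-fold lower number from compound 2 to compound 3 (0.75 log units; beyond the scatter). Going by these compounds alone, compound 3, at 17600 nM, gives this pair its only numerical value, and the swap keeps the heavy-atom count of the group while exchanging carbon for oxygen. The full size of the step stays unknown because compound 2 is recorded only as a limit of the assay: the limit of > 100000 nM in this assay, at which 1 of the 3 values shown sits.

The compounds shown do not separate the effect of the entering methoxy group from that of the two leaving methyl groups. On these data alone, how an unsubstituted phenyl, a 2-hydroxyphenyl or a 2-ethoxyphenyl on the same nitrogen would read remains open.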